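Triazole methyl to trifluoromethyl in the aryloxy-azaindole series

The source may report more compounds than this note shows. Statements on the series, on what has been measured and on what is new or still open speak of the compounds shown alone.

Of the compounds shown here, three of one shared core have been measured in a functional assay on MCF7 cells (Homo sapiens) for cytotoxicity, read by MTT assay, with a stated time of 72 h; on this read-out lower numbers stand for stronger inhibition and higher numbers for weaker inhibition. Compound 1 `Cc1c(C(=O)Nc2ccc(Oc3ccnc4[nH]ccc34)cc2)nnn1-c1ccccc1` gives 320 nM. Compound 2 `Cc1c(C(=O)Nc2ccc(Oc3ccnc4[nH]ccc34)cc2)nnn1-c1ccc(F)cc1` gives 390 nM. Compound 3 `Cc1c(C(=O)Nc2ccc(Oc3ccnc4[nH]ccc34)cc2)nnn1-c1ccc(Cl)c(C(F)(F)F)c1` gives 8410 nM. Compound 2 stands second highest of the three numbers: its nearest neighbour is compound 1, with a 1.2-fold higher number from compound 1 to compound 2 (0.09 log units; within the scatter), and its furthest is compound 3, with a 22-fold higher number from compound 2 to compound 3 (1.33 log units; beyond the scatter); the step of a 26-fold higher number from compound 1 to compound 3 (1.42 log units; beyond the scatter) is of the same kind. All three measured steps change the aryl group on the ring nitrogen, none touches the substituent on the ring carbon.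

Compound 4 `O=C(Nc1ccc(Oc2ccnc3[nH]ccc23)cc1)c1nnn(-c2ccc(F)cc2)c1C(F)(F)F` differs from compound 2 by trifluoromethyl in place of methyl on an aromatic carbon. Within the data shown here, no measured step bears on this position, so the direction cannot be read from the series; the measured steps only show that the numbers in this assay can move widely with a single substituent change. The expectation for compound 4 is therefore set near compound 2 with a wide range: a value of 800 nM is estimated, between 250 nM and 3500 nM, which means an expected step of a 2.1-fold higher number from compound 2 to compound 4 (0.31 log units; beyond the scatter).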

Compound 4, half-maximal inhibitory concentration: 210 nM
For compound 4 the middle estimate is 3.8-fold (0.58 log units) above the measured one; the measured number lies below the stated range.
By their numbers in this assay, from the lowest: compounds 4, 1 and 2 (each within the scatter of the next); then compound 3.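

Working notes: in this assay, the first reading at the ring carbon comes from trifluoromethyl in place of methyl, with a 1.9-fold lower number from compound 2 to compound 4 (0.27 log units; within the scatter) as the step. This position, next to the ring atom that bears a 4-fluorophenyl group, therefore accepts trifluoromethyl with the 4-fluorophenyl group held constant, unlike the aryl change on the ring nitrogen, where a 22-fold higher number from compound 2 to compound 3 (1.33 log units; beyond the scatter) is a large step. No evidence on the cause of this result is available.

The compounds shown leave open whether the same exchange stays within the scatter when the ring nitrogen carries phenyl or 4-chloro-3-(trifluoromethyl)phenyl. They also leave open how the numbers respond to hydrogen, a nitrile, an amine or a longer alkyl chain on this ring carbon.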